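Swapping One Ring in a Weak Growth Inhibitor

The compounds below may be only part of what the source reports. "The series", "measured", "known", "first", "only" and "open" are said of these compounds alone.

Of the compounds shown here, three built on a shared core have been measured in a functional assay on WM 266-4 cells (Homo sapiens) for antiproliferative activity, read by MTT assay, with a stated time of 48 h; on this read-out higher numbers stand for weaker inhibition of growth and lower numbers for stronger inhibition of growth. Compound 1 `FC(F)(F)c1ccc(C2=NN(C(=S)Nc3ccccc3)C(c3ccc4c(c3)OCCO4)C2)cc1` gives 52400 nM. Compound 2 `COc1ccccc1C1=NN(C(=S)Nc2ccccc2)C(c2ccc3c(c2)OCCO3)C1` gives 25800 nM, and compound 3 `Cc1ccc(C2=NN(C(=S)Nc3ccccc3)C(c3ccc4c(c3)OCCO4)C2)cc1C` gives 70500 nM. Among these three, compound 1 holds the second highest number: its gap to compound 3 lies within the scatter, while compound 2 sits a modest step below it, as the step of a 2.0-fold lower number from compound 1 to compound 2 (0.31 log units; beyond the scatter) shows.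

Compound 4 `S=C(Nc1ccccc1)N1N=C(c2cccs2)CC1c1ccc2c(c1)OCCO2` has not yet been measured. It differs from compound 1 in one place: thiophen-2-yl in place of 4-(trifluoromethyl)phenyl on a carbon with a double bond to nitrogen

The measured steps that bear on this position all exchange the ring that sits on the carbon with a double bond to nitrogen. The step of a 2.0-fold lower number from compound 1 to compound 2 (0.31 log units; beyond the scatter) was modest and beyond the scatter, the step of a 1.3-fold higher number from compound 1 to compound 3 (0.13 log units; within the scatter) lay within it, and the step of a 2.7-fold higher number from compound 2 to compound 3 (0.44 log units; beyond the scatter) was modest. Going by the values given here, each of those replacements kept a six-membered aromatic ring of carbon only; none brought in a five-membered aromatic ring with a hetero atom, so there is no direct precedent for compound 4. The changes at this position have so far moved the number by modest amounts at most, so a small step in either direction, or none beyond the scatter, is expected for compound 4. The estimate for compound 4 is 40000 nM, with a range of 15000 nM to 110000 nM, which corresponds to an expected step of a 1.3-fold lower number from compound 1 to compound 4 (0.12 log units; within the scatter).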

Compound 4, concentration for 50% growth inhibition: 154000 nM
Compound 4: middle estimate off by 3.9-fold (0.59 log units), on the low side; measured number above the stated range.
By their numbers in this assay, from the lowest: compound 2; then compounds 1 and 3 (each within the scatter of the next); then compound 4.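

In this assay, thiophen-2-yl, the only five-membered aromatic ring with a hetero atom at this position, gives the weakest growth inhibition of the four compounds, with a 2.9-fold higher number from compound 1 to compound 4 (0.47 log units; beyond the scatter), a 2.2-fold higher number from compound 3 to compound 4 (0.34 log units; beyond the scatter) and a 6.0-fold higher number from compound 2 to compound 4 (0.78 log units; beyond the scatter). All three six-membered aromatic rings of carbon only therefore give lower numbers than this ring, despite their different substituents, and the last of these steps is larger than the widest step among those six-membered rings alone, a 2.7-fold higher number from compound 2 to compound 3 (0.44 log units; beyond the scatter). The position thus tolerates ring exchange less evenly than the earlier compounds suggested, but no measurement shown here accounts for the rise in the number.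

This single change replaces a six-membered ring with a five-membered one, swaps carbon-only aromatic atoms for a ring containing sulfur, and removes the trifluoromethyl group, so the compounds shown cannot separate these differences. Unsubstituted phenyl and furan-2-yl, which has oxygen in place of sulfur, would help to pull them apart, while whether an amine or a carboxylic acid on the ring at this position would lower the number remains open.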